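The compounds below may be only part of what the source reports. "The series", "measured", "known", "first", "only" and "open" are said of these compounds alone.

Values in a functional assay on HL-60 cells (Homo sapiens) for antiproliferative activity, read by MTT assay, with a stated time of 72 h; on this read-out higher numbers stand for weaker inhibition and lower numbers for stronger inhibition:
Compound 1 `COc1cc(C(=O)c2sc3ccccc3c2-c2ccc(SC)cc2)cc(OC)c1OC`: 1300 nM
Compound 2 `COc1ccc(-c2c(C(=O)c3cc(OC)c(OC)c(OC)c3)sc3ccccc23)c(OC)c1`: 4600 nM
Compound 3 `COc1ccc(OC)c(-c2c(C(=O)c3cc(OC)c(OC)c(OC)c3)sc3ccccc23)c1`: > 10000 nM (a limit, not a number)

Compound 3 stands at the limit of > 10000 nM in this assay, at which 1 of the 3 values shown sits, so only a limit is known for it. Compound 4 `COc1ccc(-c2c(C(=O)c3cc(OC)c(OC)c(OC)c3)sc3ccccc23)cc1C` carries 4-methoxy-3-methylphenyl in place of 2,5-dimethoxyphenyl on an aromatic carbon.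

All three measured steps swap this same aryl group. Changing to 2,4-dimethoxyphenyl gave a 3.5-fold higher number from compound 1 to compound 2 (0.55 log units; beyond the scatter). Changing to 2,5-dimethoxyphenyl gave an at least 7.6-fold higher number from compound 1 to compound 3 (0.88 log units; beyond the scatter). Between the two dimethoxyphenyl groups the step was an at least 2.1-fold higher number from compound 2 to compound 3 (0.33 log units; beyond the scatter). Of the three groups, 2,5-dimethoxyphenyl therefore does worst, and removing it should give a clearly lower number. The entering group keeps a 4-methoxy, as the 2,4-dimethoxyphenyl group of compound 2 does, and compound 2 gives 4600 nM. With so few compounds, this expectation remains loose.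

In this assay the expected change is an at least 5.5-fold lower number from compound 3 to compound 4 (0.74 log units; beyond the scatter). Compound 4 is estimated at 1800 nM, with an expected range from 500 nM to 6500 nM.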

Compound 4, half-maximal inhibitory concentration: > 10000 nM
Compound 4 was reported as a limit (the forecaster's own chance of this, stated with the estimate: 12%); at least 5.5-fold (0.74 log units) between middle value and limit.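

In this assay compound 4 gives > 10000 nM, which is a limit and not a number. Keeping a 4-methoxy on this aryl group therefore does not by itself hold the activity: moving to 4-methoxy-3-methylphenyl gave an at least 2.1-fold higher number from compound 2 to compound 4 (0.33 log units; beyond the scatter), and the comparison with 4-(methylsulfanyl)phenyl gave an at least 7.6-fold higher number from compound 1 to compound 4 (0.88 log units; beyond the scatter). Compound 3 and compound 4 both end at a limit, so the step between them cannot be read and their two groups cannot be ranked: the limit of > 10000 nM in this assay, at which 2 of the 4 values shown sit.

Of the four, only compound 1, at 1300 nM, has a number that is lower than those of all the others by more than the scatter. Still open, from the compounds shown here alone, is how a phenyl carrying a single methoxy and nothing else would fare, or one with an amine or a longer chain in place of the methylsulfanyl.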